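Extending the nitrogen substituent by one carbon

A few compounds are considered here, and "the series" means these few. Any claim that something is new, unique, unknown or untested is made for them only; others in the source may bear on it.

Three compounds share one core and differ only in the group carried on an aromatic nitrogen. Compound 1 `C/C(=C\C(=O)Nc1ccccc1OCCCC(=O)O)c1ccc2c(ccn2C)c1` carries a methyl there and gives 780 nM in an assay on Prostate gland for inhibition of steroid 5-alpha-reductase (Rattus norvegicus); on this read-out lower numbers stand for stronger inhibition and higher numbers for weaker inhibition. Compound 2 `CCCC(C(C)C)n1ccc2cc(/C(C)=C/C(=O)Nc3ccccc3OCCCC(=O)O)ccc21` carries a 1-isopropylbutyl and gives 7.2 nM. Compound 3 `C/C(=C\C(=O)Nc1ccccc1OCCCC(=O)O)c1ccc2c(ccn2C(C)c2ccccc2)c1` carries a 1-phenylethyl and gives 19 nM, which places it second of the three numbers: the step of a 41-fold lower number from compound 1 to compound 3 (1.61 log units; beyond the scatter) is large, while the step of a 2.6-fold higher number from compound 2 to compound 3 (0.42 log units; beyond the scatter) is modest.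

Compound 4 `CCC(c1ccccc1)n1ccc2cc(/C(C)=C/C(=O)Nc3ccccc3OCCCC(=O)O)ccc21` is not yet measured. It differs from compound 3 by methyl in place of hydrogen on a saturated chain carbon, two bonds along the chain from an aromatic carbon and an aromatic nitrogen, so the 1-phenylethyl becomes a 1-phenylpropyl. Among the measured compounds shown here, the steps that bear on this are a 110-fold lower number from compound 1 to compound 2 (2.03 log units; beyond the scatter) and a 41-fold lower number from compound 1 to compound 3 (1.61 log units; beyond the scatter), both large, which show that a branched group on this nitrogen matters a great deal compared with methyl, and the modest step of a 2.6-fold higher number from compound 2 to compound 3 (0.42 log units; beyond the scatter), which shows that exchanging one branched group for another moves the number only a little. Adding a single carbon to an already branched group is therefore expected to give a small step, a 1.5-fold lower number from compound 3 to compound 4 (0.16 log units; within the scatter), likely within the scatter or slightly toward a lower number. Compound 4 is estimated at 13 nM, with a range from 5 nM to 35 nM.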

Compound 4, half-maximal inhibitory concentration: 19 nM
Compound 4: the middle estimate sits 1.5-fold (0.16 log units) below what was measured; low and high end bracket the measured number.
By their numbers in this assay, from the lowest: compound 2; then compounds 3 and 4 (each within the scatter of the next); then compound 1.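

Going from 1-phenylethyl to 1-phenylpropyl, a methyl in place of hydrogen on a saturated chain carbon, gives in this assay the step of no change at the digits printed from compound 3 to compound 4 (within the scatter) and so shows that this chain carbon takes one more carbon with no change that can be told from the scatter. The standing of the branched group also survives the extra carbon, since the comparison with the methyl of compound 1 still reads a 41-fold lower number from compound 1 to compound 4 (1.61 log units; beyond the scatter) and is large, while the comparison with the 1-isopropylbutyl of compound 2 still reads a 2.6-fold higher number from compound 2 to compound 4 (0.42 log units; beyond the scatter) and is modest, so lengthening the chain by this one carbon does not close that remaining gap. Nothing available here accounts for the flat step or for that gap.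

As far as these compounds go, with only one added carbon in view, it remains open whether a longer chain, such as the 1-phenylbutyl group, would leave the number equally unmoved. Also open is what an amine or a hydroxyl group on the same saturated chain carbon would do to inhibition, since every nitrogen substituent shown is built from carbon and hydrogen alone.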